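This account rests on a few compounds, and the source may have more. Where it says the series, first, only, none or still open, it means among the compounds named here.

Compound 1, `COc1cc2cc(Oc3ccc(NC(=O)Nc4cccc(C(F)(F)F)c4)cc3)c(C)nc2cc1OC`: -23.5%
Compound 2, `COc1cc2cc(Oc3ccc(NC(=O)Nc4ccc(Cl)c(C(F)(F)F)c4)cc3)c(C)nc2cc1OC`: 4.49%

In a functional assay on NCI-H226 cells (Homo sapiens) for inhibition, read by sulforhodamine B assay, with a stated time of 48 h, tested at 10 uM (a lower number here means a stronger effect, a higher number a weaker effect of the compound at the concentration tested), compound 2 gives 4.49%, the higher of the two numbers recorded so far, meaning the weaker effect. Compound 1 gives -23.5%, the lower of the two. For the measured compounds named here, the only step between measured compounds is a number 28 percentage points higher from compound 1 to compound 2 (beyond the scatter), a change on the aromatic ring that carries the trifluoromethyl group.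

Compound 3, `COc1cc2cc(Oc3ccc(NC(=O)Nc4ccc(Cl)c(Cl)c4)cc3)c(C)nc2cc1OC`, has not yet been measured. It differs from compound 2 in one place: chloro in place of trifluoromethyl on an aromatic carbon. Going by the values given here, no measured step involves this exchange of trifluoromethyl for chloro, so the one known step offers no direct guide to its size or direction. With the compound otherwise unchanged, compound 3 is expected to stay close to compound 2, giving an estimated step of a number 0.5 percentage points higher from compound 2 to compound 3 (within the scatter), within the usual scatter. For compound 3 the expected value is 5%, with a likely range from -15% to 25%.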

Compound 3, a percentage reported as activity, at one concentration (the size of the read-out at that concentration, not a potency): 7.74%
Estimate against measurement, compound 3: 2.7 percentage points below; the measured number falls inside the stated range.
By their numbers in this assay, from the lowest: compound 1; then compounds 2 and 3 (each within the scatter of the next).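

In this assay, putting chloro in place of trifluoromethyl on this aromatic carbon, ortho to a chloro group, gives a number 3.3 percentage points higher from compound 2 to compound 3 (within the scatter), so this pair does not separate the two groups, although one has a single heavy atom and the other has four. Putting 3,4-dichlorophenyl in place of 3-(trifluoromethyl)phenyl gives a number 31.2 percentage points higher from compound 1 to compound 3 (beyond the scatter), so this second ring with two groups also has a weaker effect at the concentration tested than the ring with trifluoromethyl alone. Nothing available explains why chloro and trifluoromethyl read alike here.

Going by these compounds, whether a methoxy group, a nitrile or an amine on this same aromatic carbon would read like chloro and trifluoromethyl stays open. These numbers also come from one concentration, so they show only a stronger or weaker effect at that concentration.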